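A few compounds are considered here, and "the series" means these few. Any claim that something is new, unique, unknown or untested is made for them only; others in the source may bear on it.

Measured so far:
compound 1 `O=C(C(Nc1ccccc1F)c1ccc(C(F)(F)F)cc1)N1CCCC1c1ccccc1F` gives 7 nM in an assay on HEK293 cells for antagonist activity at transient receptor potential M8 protein (Canis lupus familiaris), read by fluorescence and calcium flux, with a stated time of 5 min; on this read-out higher numbers stand for weaker inhibition and lower numbers for stronger inhibition
compound 2 `O=C(C(Nc1ccc(F)cc1)c1ccc(C(F)(F)F)cc1)N1CCCC1c1ccccc1Cl` gives 73 nM in this assay

Compound 1 holds the lowest of the two numbers; compound 2 stands a tenth-power higher, beyond the scatter, and the two differ in more than one place, so only the two values themselves are of use. Compound 3 `O=C(C(Nc1ccccc1F)c1ccc(C(F)(F)F)cc1)N1CCCC1c1cccnc1` departs from compound 1 by pyridin-3-yl in place of 2-fluorophenyl on a saturated ring carbon. Among the measured compounds shown here, no step of this kind between measured compounds exists here. A moderate move toward weaker inhibition is expected, as a 2.9-fold higher number from compound 1 to compound 3 (0.46 log units; beyond the scatter), with the range allowing for no change. Compound 3 is estimated at 20 nM in this assay, between 5 nM and 80 nM.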

Compound 3, half-maximal inhibitory concentration: 7 nM
For compound 3 the middle estimate is 2.9-fold (0.46 log units) above the measured one; the range from low to high includes it.
By their numbers in this assay, from the lowest: compounds 1 and 3 (each within the scatter of the next); then compound 2.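

Pyridin-3-yl in place of 2-fluorophenyl on the saturated ring carbon reads in this assay as no change at the digits printed from compound 1 to compound 3 (within the scatter) and so shows that this position accepts a six-membered aromatic ring with a hetero atom and a hydrogen-bond acceptor. The fluorine of the 2-fluorophenyl is therefore not required for a value at this level. No measurement at hand gives a reason for this result.

Open, from the compounds shown here alone, is whether the place of the ring nitrogen matters, as pyridin-2-yl or pyridin-4-yl would show. Also open, going by these compounds, is how unsubstituted phenyl or morpholine would read on this carbon.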